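The source may report more compounds than this note shows. Statements on the series, on what has been measured and on what is new or still open speak of the compounds shown alone.

Compound 1 `O=C1CCC(=O)N1S(=O)(=O)c1ccc(-c2ccccc2)cc1` gives 700 nM in an assay on membranes from HEK293T cells for inhibition of presenilin-associated rhomboid-like protein, mitochondrial (Homo sapiens), with a stated time of 30 min; a lower number here means a stronger inhibitor, a higher number a weaker inhibitor.
Compound 2 `O=C1CCC(=O)N1S(=O)(=O)c1ccc([N+](=O)[O-])cc1` gives 900 nM in this assay.

Going by the values given here, compound 2 stands highest of the two numbers in this assay, though the only step leading to it lies within the scatter: a 1.3-fold higher number from compound 1 to compound 2 (0.11 log units; within the scatter). Compound 3 `O=C1CCC(=O)N1S(=O)(=O)c1ccccc1` differs from compound 2 by hydrogen in place of nitro on an aromatic carbon. No measured step removes the group at that position outright; the one step shown only exchanges phenyl for nitro without a change beyond the scatter. Compound 3 is therefore expected to give a somewhat higher number, a 2.2-fold higher number from compound 2 to compound 3 (0.35 log units; beyond the scatter), with wide uncertainty. The estimate for compound 3 in this assay is 2000 nM, ranging from 700 nM to 6000 nM.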

Compound 3, half-maximal inhibitory concentration: 4300 nM
Compound 3: middle estimate off by 2.2-fold (0.33 log units), on the low side; low and high end bracket the measured number.
By their numbers in this assay, from the lowest: compounds 1 and 2 (each within the scatter of the next); then compound 3.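

The step that matters at this position is loss of the substituent, not exchange of one group for another. In this assay, there is a 4.8-fold higher number from compound 2 to compound 3 (0.68 log units; beyond the scatter), and there is a 6.1-fold higher number from compound 1 to compound 3 (0.79 log units; beyond the scatter), so among these compounds either nitro or phenyl on this aromatic carbon gives a lower number than hydrogen. No experimental data bear on why this is so.

From the compounds shown here alone, whether an amine or a carboxylic acid at this place would also give a lower number than hydrogen stays open. So does the effect of moving nitro or phenyl elsewhere on the ring.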